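Moving One Hydroxyl Group on Compound 1

A few compounds are considered here, and "the series" means these few. Any claim that something is new, unique, unknown or untested is made for them only; others in the source may bear on it.

Measured in a functional assay on OVCAR-5 cells (Homo sapiens) for inhibition, read by CCK-8 assay, with a stated time of 72 h, tested at 1 uM; a higher number here means more inhibition of growth at the concentration tested, a lower number less inhibition of growth:
compound 1 `CN(C)C(=O)c1cc2cnc(Nc3ccc(NC(=O)C4(C(=O)Nc5cccc(O)c5)CC4)cc3)nc2n1C1CCCC1`: 58.5%
compound 2 `Nc1ccc(NC(=O)C2(C(=O)Nc3ccc(F)cc3)CC2)cc1F`: 6.7%
compound 3 `CN(C)C(=O)c1cc2cnc(Nc3ccc(NC(=O)C4(C(=O)Nc5ccc(F)cc5)CC4)cc3F)nc2n1C1CCCC1`: -0.9%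

In this assay, compound 1 stands highest of the three, and its gap to each of the other two lies beyond the usual scatter of repeated measurements. Compound 3 shares the core of compound 1 but differs from it in more than one place, and compound 2 is a much smaller molecule, so neither shows the effect of one isolated change.

Compound 4 `CN(C)C(=O)c1cc2cnc(Nc3ccc(NC(=O)C4(C(=O)Nc5ccc(O)cc5)CC4)cc3)nc2n1C1CCCC1` has not yet been measured. Its difference from compound 1 is small: 4-hydroxyphenyl in place of 3-hydroxyphenyl on an amide-type nitrogen. In words, it carries 4-hydroxyphenyl in place of 3-hydroxyphenyl on an amide-type nitrogen, so the two have the same atoms, joined differently. Among the compounds with values here, no measured pair shows what such a move does, so any expectation stays loose. Starting from compound 1 at 58.5%, a moderate fall seems somewhat likelier than a rise. The expected step is a modest drop, estimated as a number 13.5 percentage points lower from compound 1 to compound 4 (beyond the scatter). For compound 4 the estimated value is 45%, with an expected range from 15% to 70%.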

Compound 4, percent growth inhibition at one concentration: 80.7%
Beside the measured number, compound 4's estimate is 35.7 percentage points below it; the measured number lies above the stated range.
By their numbers in this assay, from the lowest: compounds 3 and 2 (each within the scatter of the next); then compound 1; then compound 4.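

Read in this assay the move gives a number 22.2 percentage points higher from compound 1 to compound 4 (beyond the scatter) and this is the first pair here that differs in one place only. Both compounds have the same atoms and the same shared core. Compound 4, with 4-hydroxyphenyl on the amide-type nitrogen, gives more inhibition of growth than compound 1, with 3-hydroxyphenyl there. No measurement shown here gives a reason for this difference.

The compounds shown leave open whether the hydroxyl group itself matters, as 4-methoxyphenyl or 4-aminophenyl on the same nitrogen would test. A single concentration on a single cell line also leaves open how compound 1 and compound 4 would compare at other doses or in other cells.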